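The compounds below may be only part of what the source reports. "The series", "measured", "known", "first", "only" and "open" are said of these compounds alone.

Measured so far:

- compound 1, `CCNc1cc(N2CCNCC2)ccc1S(=O)(=O)c1ccccc1`: 2.7 nM
- compound 2, `CNc1nn2c(C)cc(CN)nc2c1S(=O)(=O)c1ccccc1`: 0.977 nM
- compound 3, `CNc1nn2c(C)c(NC(C)=O)c(C)nc2c1S(=O)(=O)c1ccccc1`: 4.68 nM

All three were tested in a functional assay on HEK293 cells for inhibition of 5-hydroxytryptamine receptor 6 (Homo sapiens), read by cAMP accumulation; on this read-out lower numbers stand for stronger inhibition and higher numbers for weaker inhibition. Compound 3 has the highest number of the three. Its gap to compound 1 stays within the usual scatter of this assay, so the two cannot be ordered; its gap to compound 2 lies beyond the scatter, and compound 2 shows the lower number.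

Compound 4, `CNc1nn2c(C)c(CN(C)C)c(C)nc2c1S(=O)(=O)c1ccccc1`, is not yet measured. It differs from compound 3 in one place: (dimethylamino)methyl in place of acetamido on an aromatic carbon. Among the compounds with values here, no measured pair shows this same change, so there is no directly comparable step. The change is expected to move the number little, if at all, beyond the scatter, perhaps slightly downward. The expected step is a 1.9-fold lower number from compound 3 to compound 4 (0.27 log units; within the scatter). Compound 4 is therefore estimated at 2.5 nM, with a range from 0.6 nM to 10 nM.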

Compound 4, inhibition constant: 0.708 nM
Compound 4: middle estimate off by 3.5-fold (0.55 log units), on the high side; measured number inside the range.
By their numbers in this assay, from the lowest: compounds 4 and 2 (each within the scatter of the next); then compounds 1 and 3 (each within the scatter of the next).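

In this assay, this aromatic carbon, ortho to two methyl groups, proves sensitive to what it carries: putting (dimethylamino)methyl in place of acetamido gives a 6.6-fold lower number from compound 3 to compound 4 (0.82 log units; beyond the scatter). Both groups hold 4 heavy atoms, so that count does not separate them, whereas acetamido has a hydrogen-bond donor and a double bond that (dimethylamino)methyl lacks. No measurement available here explains the step.

Still open, from the compounds shown here alone, is which of those differences matters, and how a longer aminoethyl chain, a morpholine or a carboxylic acid on this carbon would compare with compound 4.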